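A 2,4-dichlorophenyl swap on compound 2

The source may report more compounds than this note shows. Statements on the series, on what has been measured and on what is new or still open speak of the compounds shown alone.

In a functional assay on K562 cells (Homo sapiens) for inhibition, read by MTT assay, with a stated time of 48 h (a lower number here means a stronger inhibitor, a higher number a weaker inhibitor), compound 1 (`CC(C)(C)OC(=O)N1C[C@@H](n2cc(-c3ccc4c(N)n[nH]c4c3)nn2)C[C@H]1C(=O)Nc1ccc(Cl)cc1Cl`) gives 12200 nM and compound 2 (`CC(C)(C)OC(=O)N1C[C@@H](n2cc(-c3ccc4nc(N)sc4n3)nn2)C[C@H]1C(=O)Nc1ccc(Cl)c(C(F)(F)F)c1`) gives 10900 nM. These two numbers lie within the usual scatter of each other, so compound 2 stands level with compound 1.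

Compound 3 (`CC(C)(C)OC(=O)N1C[C@@H](n2cc(-c3ccc4nc(N)sc4n3)nn2)C[C@H]1C(=O)Nc1ccc(Cl)cc1Cl`) keeps the core of compound 2 and changes one group: 2,4-dichlorophenyl in place of 4-chloro-3-(trifluoromethyl)phenyl on an amide-type nitrogen. Going by the values given here, no measured pair isolates this change. The entering group already stands on compound 1, which gives 12200 nM. Compound 2 gives 10900 nM, and the two numbers do not separate. No step beyond the scatter is therefore expected in this assay, in either direction. The estimated step of a 1.0-fold higher number from compound 2 to compound 3 (0.00 log units; within the scatter) stays within the scatter. For compound 3 the expected value is 11000 nM, with an estimated range of 5500 nM to 22000 nM.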

Compound 3, half-maximal inhibitory concentration: 8940 nM
Compound 3: middle estimate off by 1.2-fold (0.09 log units), on the high side; the range from low to high includes it.
By their numbers in this assay, from the lowest: compounds 3, 2 and 1 (each within the scatter of the next).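

In this assay, going by these compounds alone, 2,4-dichlorophenyl in place of 4-chloro-3-(trifluoromethyl)phenyl on an amide-type nitrogen gives the first direct reading of this change (a 1.2-fold lower number from compound 2 to compound 3 (0.09 log units; within the scatter)), and the two groups are not told apart at this position. Compound 3 also forms a pair with compound 1, which differs from it in one place, the group on an aromatic carbon; that exchange likewise separates nothing (a 1.4-fold lower number from compound 1 to compound 3 (0.14 log units; within the scatter)), so neither place shows a step beyond the scatter in this assay. Nothing at hand bears on the reason for these readings.

The compounds shown leave open whether a group of another kind on the amide-type nitrogen, such as a cyclohexyl or pyridyl ring, would move the number beyond the scatter. Also open, as far as these compounds go, is what a free amine in place of the tert-butoxycarbonyl group would give.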